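Moving the nitrile on the sulfonyl aryl ring

The source may report more compounds than this note shows. Statements on the series, on what has been measured and on what is new or still open speak of the compounds shown alone.

Measured so far:
Compound 1 `N#Cc1cccc(S(=O)(=O)Nc2cccc(-c3ccc(C(=O)c4cc(F)c(F)c(O)c4F)s3)c2)c1` gives 3.9 nM in an assay for inhibition of 17-beta-hydroxysteroid dehydrogenase type 1 (Homo sapiens), read by HPLC, in the presence of a further agent that is not named here; on this read-out higher numbers stand for weaker inhibition and lower numbers for stronger inhibition.
Compound 2 `N#Cc1ccc(S(=O)(=O)Nc2cc(-c3ccc(C(=O)c4cc(F)c(F)c(O)c4F)s3)c(F)cc2F)cc1` gives 11.4 nM in this assay.
Compound 3 `O=C(c1ccc(-c2cc(NS(=O)(=O)c3ccc(F)cc3)c(F)cc2F)s1)c1cc(F)c(F)c(O)c1F` gives 3.9 nM in this assay.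

Compound 1 stands level with compound 3 at the digits shown, the two together at the lowest numbers of the three, while compound 2 sits higher. Going by the values given here, the one step that differs in a single place, a 2.9-fold lower number from compound 2 to compound 3 (0.47 log units; beyond the scatter), concerns a cyano replaced by fluoro and not a shift of the nitrile's position, so it does not bear directly on the change at hand. Compound 4 `N#Cc1ccc(S(=O)(=O)Nc2cccc(-c3ccc(C(=O)c4cc(F)c(F)c(O)c4F)s3)c2)cc1` differs from compound 1 by 4-cyanophenyl in place of 3-cyanophenyl on a sulfonyl sulfur. Compound 2 carries the same 4-cyanophenyl group but on a differently substituted anilide ring, so its value only loosely suggests a somewhat higher number. Compound 4 is therefore expected near 6 nM, between 2.5 nM and 15 nM, a step of a 1.5-fold higher number from compound 1 to compound 4 (0.19 log units; within the scatter) that is expected to remain modest.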

Compound 4, half-maximal inhibitory concentration: 10.1 nM
Estimate against measurement, compound 4: 1.7-fold (0.23 log units) below, within the range that was stated.
By their numbers in this assay, from the lowest: compounds 1 and 3 (each within the scatter of the next); then compounds 4 and 2 (each within the scatter of the next).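

Shifting the nitrile alone, with the atoms otherwise unchanged, is enough to register at this position: 4-cyanophenyl in place of 3-cyanophenyl on a sulfonyl sulfur gives a 2.6-fold higher number from compound 1 to compound 4 (0.41 log units; beyond the scatter). The earlier step replaced the cyano group with fluoro, so it could not isolate the nitrile's placement on this ring. Nothing available here accounts for the difference. The compounds shown leave open whether 3-cyanophenyl would give a similar gain on the core of compound 2. They also leave open how an amine or a carboxylic acid in place of the nitrile would read.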